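Swapping the indole for a pyrazole on a nucleoside core

This account rests on a few compounds, and the source may have more. Where it says the series, first, only, none or still open, it means among the compounds named here.

Three nucleoside analogues share one core and differ only in the group hanging from a saturated chain carbon bound to an aromatic carbon. Compound 1 `OC[C@H]1O[C@@H](n2cnc3c(CSc4ccccc4)ncnc32)[C@H](O)[C@@H]1O` carries phenylsulfanyl there, compound 2 `OC[C@H]1O[C@@H](n2cnc3c(COc4ccccc4)ncnc32)[C@H](O)[C@@H]1O` phenoxy, and compound 3 `OC[C@H]1O[C@@H](n2cnc3c(Cn4ccc5ccccc54)ncnc32)[C@H](O)[C@@H]1O` 1H-indol-1-yl. In a functional assay on Huh-7 cells (Homo sapiens) for cytotoxicity, read by MTT assay, with a stated time of 3 days (a higher number here means that more compound is tolerated, a lower number that less compound is tolerated), compound 1 gives only a limit of > 100000 nM. In this assay compound 2 likewise gives only a limit of > 100000 nM. In this assay compound 3 gives only a limit of > 250000 nM. Because every value is a limit, the steps a step that the two limits leave unreadable from compound 1 to compound 2, a step that the two limits leave unreadable from compound 1 to compound 3 and a step that the two limits leave unreadable from compound 2 to compound 3 cannot be read; two values sit at the limit of > 100000 nM in this assay, at which 2 of the 3 values shown sit, and one at the limit of > 250000 nM in this assay, at which 1 of the 3 values shown sits. Compound 3 therefore stands at the highest limit shown, though nothing says it is better tolerated than the others.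

Compound 4 `OC[C@H]1O[C@@H](n2cnc3c(Cn4cccn4)ncnc32)[C@H](O)[C@@H]1O` differs from compound 3 by 1H-pyrazol-1-yl in place of 1H-indol-1-yl on a saturated chain carbon bound to an aromatic carbon. For the measured compounds named here, no measured step bears on this change. Since all three neighbours stay untoxic at their limits, compound 4 is expected to stay near the limit too, with a number no higher from compound 3 to compound 4 (the limit leaves the size open) as the expected step. The estimate for compound 4 is 250000 nM, ranging from 100000 nM to 1000000 nM.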

Compound 4, half-maximal cytotoxic concentration: > 250000 nM
Compound 4: only a limit was reported; the forecaster's own chance of this, stated with the estimate: 85%; the middle value sits exactly at the limit.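

In this assay compound 4 gives only a limit, > 250000 nM. For the compounds shown here, no step to compound 4 from compound 1, compound 2 or compound 3 can be read. The compounds shown leave open at what concentration any of the four would harm these cells, and whether swapping the group changes that concentration.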